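Swapping the hydroxyphenyl for a nitrophenyl

The source may hold more compounds than are shown below. What is called first, only, known or untested is meant among the compounds shown, and "the series" means these compounds.

Compound 1 `Cn1c(=O)c(=O)n(C2CCCC2)c2nc(N/N=C/c3ccc(O)cc3)ncc21` and compound 2 `Cn1c(=O)c(=O)n(C2CCCC2)c2nc(N/N=C/c3ccc(F)cc3Cl)ncc21` share one core and differ only in the group on the carbon with a double bond to nitrogen. In a functional assay on A549 cells (Homo sapiens) for antiproliferative activity, read by MTT assay (a lower number here means a stronger inhibitor, a higher number a weaker inhibitor), compound 1 gives > 100000 nM, which is a limit of the assay rather than a measured number. Compound 2 gives 11000 nM in this assay. Going by the values given here, the single measured step, an at least 9.0-fold lower number from compound 1 to compound 2 (0.95 log units; beyond the scatter), is known only as a lower bound because compound 1 sits at the limit of > 100000 nM in this assay, at which 1 of the 2 values shown sits.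

Compound 3 `Cn1c(=O)c(=O)n(C2CCCC2)c2nc(N/N=C/c3cccc([N+](=O)[O-])c3)ncc21` carries the change (3-nitrophenyl in place of 4-hydroxyphenyl on a carbon with a double bond to nitrogen). Like the measured step, this swap removes the 4-hydroxyphenyl, but the incoming 3-nitrophenyl is not the 2-chloro-4-fluorophenyl of compound 2, so that step is only a rough guide. Compound 3 is therefore expected to fall at 20000 nM, within 5000 nM to 100000 nM, an estimated step of an at least 5.0-fold lower number from compound 1 to compound 3 (0.69 log units; beyond the scatter).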

Compound 3, half-maximal inhibitory concentration: 12300 nM
For compound 3 the middle estimate is 1.6-fold (0.21 log units) above the measured one; the measured number falls inside the stated range.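

Two very different groups on the carbon with a double bond to nitrogen now read alike, and both differ from the 4-hydroxyphenyl: in this assay, the 3-nitrophenyl gives an at least 8.1-fold lower number from compound 1 to compound 3 (0.91 log units; beyond the scatter). Set against each other, the two incoming groups give a 1.1-fold higher number from compound 2 to compound 3 (0.05 log units; within the scatter), so the 3-nitrophenyl and the 2-chloro-4-fluorophenyl cannot be told apart in this assay. Among these three compounds, then, the lower number is not special to the chlorine and fluorine of compound 2.

Going by these compounds, the true size of the step away from compound 1 remains unknown because that compound sits at a limit of the assay: the limit of > 100000 nM in this assay, at which 1 of the 3 values shown sits. Also open is whether losing the hydroxyl alone explains the difference, which a plain phenyl would test, and how an amine or a carboxylic acid on the ring would read.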